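The compounds below may be only part of what the source reports. "The series", "measured", "known", "first", "only" and "open" are said of these compounds alone.

Working notes on the series. In a functional assay on CHO cells for agonist activity at Free fatty acid receptor 1 (Homo sapiens), read by FLIPR and calcium flux (a lower number here means that less compound is needed, a higher number that more compound is needed for the effect), compound 1 `Cc1ccc(OCC(C)C)cc1-c1cccc(COc2ccc(OCC(=O)O)c(F)c2)c1` gives 1450 nM, and compound 2 `Cc1ccc(OCCC2CCCCC2)cc1-c1cccc(COc2ccc(OCC(=O)O)c(F)c2)c1` gives 520 nM. Within the data shown here, compound 2 has the lowest of the two numbers measured so far; the only other compound, compound 1, sits higher, and the step of a 2.8-fold lower number from compound 1 to compound 2 (0.45 log units; beyond the scatter) shows that the change from isopropyl to cyclohexylmethyl on the saturated chain carbon bound to the oxygen on the aromatic ring moved the number down. Compound 3 `COc1ccc(C)c(-c2cccc(COc3ccc(OCC(=O)O)c(F)c3)c2)c1` is not yet measured. It differs from compound 2 as follows: hydrogen in place of cyclohexylmethyl on a saturated chain carbon bound to an oxygen on an aromatic ring. Among the measured compounds shown here, the one step that bears on this is a 2.8-fold lower number from compound 1 to compound 2 (0.45 log units; beyond the scatter), which ran in the other direction, with the larger group giving the lower number. Removing the cyclohexylmethyl entirely is therefore expected to give a higher number, and the step for compound 3 is estimated at a 6.7-fold higher number from compound 2 to compound 3 (0.83 log units; beyond the scatter). For compound 3 the expected value in this assay is 3500 nM, with a range of 1200 nM to 10000 nM.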

Compound 3, half-maximal effective concentration: 260 nM
For compound 3 the middle estimate is 13-fold (1.13 log units) above the measured one; the whole stated range lies above it.
By their numbers in this assay, from the lowest: compounds 3 and 2 (each within the scatter of the next); then compound 1.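

In this assay the step of a 2.0-fold lower number from compound 2 to compound 3 (0.30 log units; within the scatter) leaves the methoxy of compound 3 level with the 2-cyclohexylethoxy of compound 2, so the cyclohexylmethyl group is not required to reach this range. The step of a 5.6-fold lower number from compound 1 to compound 3 (0.75 log units; beyond the scatter) stands against the reading of the earlier pair that a larger group gives the lower number, since hydrogen in place of isopropyl on the saturated chain carbon bound to the oxygen also gives a lower number, and across the three compounds the order does not run with the size of the group. No measurement at hand bears on the reason for this.

Still open, going by these compounds, is whether an ethoxy or a straight propoxy chain reads with compound 3 or with compound 1. Also open, on these data alone, is how an amine or a carboxylic acid at the end of a longer chain would read here.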